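The source may hold more compounds than are shown below. What is called first, only, known or untested is meant among the compounds shown, and "the series" means these compounds.

Going by the values given here, compound 2 `O=C(Cn1c(=O)oc2ccccc21)Nc1nc2ccc([N+](=O)[O-])cc2s1` stands lowest of the two numbers measured so far: in an ADME assay on RAW264.7 cells (Mus musculus) for cytotoxicity, read by MTT assay, with a stated time of 72 h, tested at 100 uM (on this read-out higher numbers stand for a stronger effect at the one concentration tested and lower numbers for a weaker effect), compound 2 gives 19.2%, whereas compound 1 `O=C(Cn1c(=O)oc2ccccc21)Nc1nc2ccccc2s1` gives 59.6%. Compound 3 `O=C(Cn1c(=O)oc2cc([N+](=O)[O-])ccc21)Nc1nc2ccc([N+](=O)[O-])cc2s1` has not yet been measured; it differs from compound 2 by nitro in place of hydrogen on an aromatic carbon, the new group sitting on an aromatic carbon of a six-membered aromatic ring of carbon only, part of a fused system of two rings, meta to a fused ring and para to a fused ring. Among the compounds with values here, the one step that bears on this change is the same kind of replacement on the other ring of the shared core, which gave a number 40.4 percentage points lower from compound 1 to compound 2 (beyond the scatter) in this assay, a large fall. That step is only a partial guide, as the ring carrying the group is a different one and compound 2 already lies low, leaving less room to fall. Compound 3 is therefore expected to show a further but smaller downward step, a number 7.2 percentage points lower from compound 2 to compound 3 (within the scatter). For compound 3 the estimate in this assay is 12%, with a range from 0% to 35%.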

Compound 3, a percentage reported as inhibition, at one concentration (the size of the read-out at that concentration, not a potency): 39%
Beside the measured number, compound 3's estimate is 27 percentage points below it; measured number outside the range, above it.
By their numbers in this assay, from the lowest: compound 2; then compound 3; then compound 1.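

In this assay, nitro in place of hydrogen on an aromatic carbon does not move the number in one direction: on the ring changed first the replacement gave a number 40.4 percentage points lower from compound 1 to compound 2 (beyond the scatter), whereas at this new place, meta to a fused ring and para to a fused ring, it gives a number 19.8 percentage points higher from compound 2 to compound 3 (beyond the scatter). The effect of this replacement therefore depends on where the nitro sits, at least across compound 1, compound 2 and compound 3, and the earlier step cannot be carried over from one ring of the shared core to the other. Nothing shown gives a reason for the rise at this position.

Going by these compounds alone, whether the rise needs the nitro already present on the other ring stays open, as the change at this place is seen only on the background of compound 2. Also open, as far as these compounds go, is whether an amine or a carboxylic acid at this same place would raise the number as nitro does, or whether the rise is particular to nitro.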